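The source may hold more compounds than are shown below. What is called first, only, known or untested is meant among the compounds shown, and "the series" means these compounds.

Measured so far in an ADME assay on HepG2 2.2.15 cells (Homo sapiens) for cytotoxicity; a higher number here means that more compound is tolerated, a lower number that less compound is tolerated:
- compound 1 `CCC(=O)OCCc1c(-c2ccccc2Cl)c2cc(Cl)ccc2[nH]c1=O` gives 95000 nM
- compound 2 `CC(C)C(=O)OCCc1c(-c2ccccc2Cl)c2cc(Cl)ccc2[nH]c1=O` gives 62000 nM
- compound 3 `CC(=O)N1CCC(C(=O)OCCc2c(-c3ccccc3Cl)c3cc(Cl)ccc3[nH]c2=O)CC1` gives 82000 nM

All three values lie within the scatter of one another, so compound 3 (at 82000 nM) has no meaningful rank in this small set.

The next step leads to compound 4 `O=C(OCCc1c(-c2ccccc2Cl)c2cc(Cl)ccc2[nH]c1=O)c1cccs1`, which carries thiophen-2-yl in place of 1-acetylpiperidin-4-yl on a carbonyl carbon.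

For the measured compounds named here, three measured steps bear on this change. All of them alter the group at this carbonyl: a 1.5-fold lower number from compound 1 to compound 2 (0.19 log units; within the scatter), a 1.2-fold lower number from compound 1 to compound 3 (0.06 log units; within the scatter) and a 1.3-fold higher number from compound 2 to compound 3 (0.12 log units; within the scatter). Across these three compounds, no change at this place has moved this assay beyond the scatter. None of them, however, has an aromatic ring at this place, so the range is kept wide.

The expected result is a 1.2-fold lower number from compound 3 to compound 4 (0.08 log units; within the scatter), which would be no real change. For compound 4 the estimated value is 68000 nM, with an expected range from 32000 nM to 120000 nM.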

Compound 4, half-maximal cytotoxic concentration: > 1700000 nM
Compound 4 was reported as a limit; the forecaster's own chance of this, stated with the estimate: 12%; at least 25-fold (1.39 log units) between middle value and limit.
By their numbers in this assay, from the lowest: compounds 2, 3 and 1 (each within the scatter of the next). At a limit, above all of these: compound 4.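

In this assay compound 4 is reported only as a limit, not as a number: (the limit of > 1700000 nM in this assay, at which 1 of the 4 values shown sits). Thiophen-2-yl on this carbonyl carbon gives the first change at this place that lies beyond the scatter, and the step is large against each of the other three groups (an at least 20-fold higher number from compound 3 to compound 4 (1.31 log units; beyond the scatter); an at least 27-fold higher number from compound 2 to compound 4 (1.43 log units; beyond the scatter); an at least 17-fold higher number from compound 1 to compound 4 (1.25 log units; beyond the scatter)). This place is therefore not indifferent in this assay: ethyl, isopropyl and 1-acetylpiperidin-4-yl stay within the scatter of one another, and compound 4 alone, with the only aromatic ring here, stands apart.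

One compound cannot show whether the shift belongs to aromatic rings in general or to thiophen-2-yl itself. Phenyl or furan-2-yl at this carbonyl carbon would separate the two, and the effect of an amine or a carboxylic acid on the thiophene ring remains open.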